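Amide aryl change from compound 2 to compound 3

The source may hold more compounds than are shown below. What is called first, only, known or untested is meant among the compounds shown, and "the series" means these compounds.

In an ADME assay on MT4 cells (Homo sapiens) for cytotoxicity, read by MTT assay, with a stated time of 5 days (a higher number here means that more compound is tolerated, a lower number that less compound is tolerated), compound 1 `COc1cc2nc([S+]([O-])CC(=O)Nc3ccccc3[N+](=O)[O-])nc(Nc3c(Cl)cc(/C=C/C#N)cc3Cl)c2cc1OC` gives > 199000 nM, which is a limit of the assay and not a number. Among the measured compounds shown here, compound 2 `COc1cc2nc([S+]([O-])CC(=O)Nc3ccc(C(F)(F)F)cc3)nc(Nc3c(Cl)cc(/C=C/C#N)cc3Cl)c2cc1OC` gives 22000 nM, the only actual number so far. Compound 3 `COc1cc2nc([S+]([O-])CC(=O)Nc3cc([N+](=O)[O-])ccc3F)nc(Nc3c(Cl)cc(/C=C/C#N)cc3Cl)c2cc1OC` is still unmeasured. It differs from compound 2 as follows: 2-fluoro-5-nitrophenyl in place of 4-(trifluoromethyl)phenyl on an amide-type nitrogen. For the measured compounds named here, the one measured step bearing on this change is an at least 9.0-fold lower number from compound 1 to compound 2 (0.95 log units; beyond the scatter), which lies beyond the scatter and alters the group on the same nitrogen. Compound 1 shares a nitro group with compound 3, so part of that step is expected to reverse, although a single step is thin support. The expected step is a 2.7-fold higher number from compound 2 to compound 3 (0.44 log units; beyond the scatter), towards a higher number in this assay. For compound 3 the estimated value is 60000 nM, with an expected range of 18000 nM to 199000 nM.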

Compound 3, half-maximal cytotoxic concentration: > 194000 nM
Compound 3: a limit, no number (the forecaster's own chance of this, stated with the estimate: 25%); at least 3.2-fold (0.50 log units) between middle value and limit.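

In this assay, 2-fluoro-5-nitrophenyl on the amide-type nitrogen gives an at least 8.8-fold higher number from compound 2 to compound 3 (0.94 log units; beyond the scatter), so among the three aryl groups shown here, only 4-(trifluoromethyl)phenyl gives an actual number, while the two nitro-bearing groups do not. Compound 3 gives a limit of the assay and not a number: the limit of > 194000 nM in this assay, at which 1 of the 3 values shown sits. Compound 1 also gives a limit, so the step between compound 1 and compound 3 cannot be read, and 2-nitrophenyl and 2-fluoro-5-nitrophenyl cannot be ranked.

The compounds shown do not separate a contribution of the nitro group from that of the fluorine or from that of the trifluoromethyl group, since compound 3 differs from compound 2 in all of these at once. On these data alone, how an aryl group carrying an amine or a carboxylic acid on this nitrogen would read in this assay remains open.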